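The compounds below may be only part of what the source reports. "The series", "measured", "known", "first", "only" and "open" are said of these compounds alone.

Compound 1 `Cc1cc(COc2ccccc2)nc(-c2ccccn2)n1` gives 794 nM in a functional assay on cells for antagonist activity at Free fatty acid receptor 1 (Homo sapiens), read by TR-FRET and inositol phosphate accumulation, with a stated time of 2 h; a higher number here means a weaker inhibitor, a lower number a stronger inhibitor. Compound 2 `Cc1cc(COc2cccc(F)c2)nc(-c2ccccn2)n1` carries fluoro in place of hydrogen on an aromatic carbon, and in this assay compound 2 gives 794 nM; the step is no change at the digits printed from compound 1 to compound 2 (within the scatter). Compound 3 `Cc1cc(COc2ccc(F)cc2F)nc(-c2ccccn2)n1` has a core whose difference from the core of compound 1 is not broken down here; in this assay compound 3 gives 398 nM. Compound 4 `Cc1cc(COc2c(F)cc(F)cc2F)nc(-c2ccccn2)n1` differs from compound 3 by fluoro in place of hydrogen on an aromatic carbon. This is the same kind of change as that from compound 1 to compound 2, but not the same: there the place was meta to a large group, here it is ortho to a large group and meta to two fluoro groups. Resting on the earlier step, no change at the digits printed from compound 1 to compound 2 (within the scatter), the expected step is a 1.0-fold higher number from compound 3 to compound 4 (0.00 log units; within the scatter). Compound 4 is therefore estimated at 400 nM, with a range from 150 nM to 1000 nM.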

Compound 4, half-maximal inhibitory concentration: 1260 nM
The estimate for compound 4 lay 3.2-fold (0.50 log units) below the measured number, and the stated range ends below it.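

In this assay the added fluoro gives a 3.2-fold higher number from compound 3 to compound 4 (0.50 log units; beyond the scatter) and does not repeat the earlier step, so this change does not carry over as one fixed step between these cores: the same change on two cores in this assay, no change at the digits printed (within the scatter) from compound 1 to compound 2 and a 3.2-fold higher number (0.50 log units; beyond the scatter) from compound 3 to compound 4, 3.2-fold (0.50 log units) apart, beyond the scatter of two such steps. The new fluoro sits ortho to a large group and meta to two fluoro groups, and the earlier step was at a different place, so core and place are not separated here. One pair on each core shows that the step can vary, but it does not show the cause or give a rule for other cores.

Open, going by these compounds, is whether a lone fluoro at this same place would give the same step. Also open, on these data alone, is how chloro or methoxy there would compare.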